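Hydantoin nitrogen substituent and rat microsomal half-life

The compounds below may be only part of what the source reports. "The series", "measured", "known", "first", "only" and "open" are said of these compounds alone.

Measured so far:
- compound 1 `CCN1C(=O)CN(Cc2ccc(-c3cccc(CN4CCCCC4)n3)cc2)C1=O`: 0.95 h
- compound 2 `O=C1CN(Cc2ccc(-c3ccc(F)c(CN4CCCCC4)n3)cc2)C(=O)N1CC1CCC1`: 0.0833 h
- compound 3 `CN1C(=O)CN(Cc2ccc(-c3cccc(CN4CCCCC4)n3)cc2)C1=O`: 1.5 h

In an in vitro ADME assay on microsomes from liver (Rattus norvegicus) for metabolic stability, read by LC-MS, using NADPH, tested at 1 uM (a lower number here means that the compound disappears faster, a higher number that the compound lasts longer), compound 3 gives the highest of the three numbers; compound 1 is nearest and within the scatter, compound 2 furthest and beyond it. Compound 4 `CC(C)N1C(=O)CN(Cc2ccc(-c3cccc(CN4CCCCC4)n3)cc2)C1=O` differs from compound 3 in one place: isopropyl in place of methyl on an amide-type nitrogen in a ring. Among the measured compounds shown here, the only one-place step on this nitrogen, a 1.6-fold higher number from compound 1 to compound 3 (0.20 log units; within the scatter), lies within the scatter. Compound 2 carries a larger group on the same nitrogen together with a second change, so its much lower number is not a clean guide. A modest downward step is therefore expected, a 2.1-fold lower number from compound 3 to compound 4 (0.33 log units; beyond the scatter), and compound 4 is estimated at 0.7 h (range 0.25 h to 1.8 h).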

Compound 4, half-life in the Rattus norvegicus assay: 0.75 h
Compound 4: the middle estimate sits 1.1-fold (0.03 log units) below what was measured; the measured number falls inside the stated range.
By their numbers in the Rattus norvegicus assay, from the lowest: compound 2; then compounds 4, 1 and 3 (each within the scatter of the next).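

In the Rattus norvegicus assay, isopropyl in place of methyl on this amide-type nitrogen in a ring gives a 2.0-fold lower number from compound 3 to compound 4 (0.30 log units; within the scatter), and the other step gives a 1.3-fold lower number from compound 1 to compound 4 (0.10 log units; within the scatter), so neither step separates these compounds on half-life. In a physicochemical assay for lipophilicity (a higher number here means a more lipophilic compound, a lower number a more polar compound), compound 3 gives 1.3 and compound 4 gives 2.2, a gap beyond the scatter. This change therefore shifts the distribution coefficient clearly while its half-life step stays within the scatter.

Still open, as far as these compounds go, is how half-life responds to a longer chain bearing an amine or a carboxylic acid on this nitrogen. Also open, from the compounds shown here alone, is whether the low number of compound 2 follows from its larger group or from its second change.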